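This account rests on a few compounds, and the source may have more. Where it says the series, first, only, none or still open, it means among the compounds named here.

Compound 1 `O=S(=O)(Nc1ccc(Cl)c(Cl)c1)c1ccc(-c2cnc(C3CC3)o2)cc1`: 62100 nM
Compound 2 `O=S(=O)(Nc1cccc(Cl)c1)c1ccc(-c2cnc(C3CC3)o2)cc1`: 54200 nM
Compound 3 `Cc1ccc(NS(=O)(=O)c2ccc(-c3cnc(C4CC4)o3)cc2)cc1C`: > 100000 nM (a limit)

In a functional assay on cells (leukaemia cell line, Homo sapiens) for inhibition, read by sulforhodamine B assay, with a stated time of 48 h (a lower number here means a stronger inhibitor of growth, a higher number a weaker inhibitor of growth), compound 3 has no number of its own and is reported only as the limit > 100000 nM. Compound 4 `O=S(=O)(Nc1ccc(I)c(Cl)c1)c1ccc(-c2cnc(C3CC3)o2)cc1` differs from it on a sulfonamide nitrogen: 3-chloro-4-iodophenyl in place of 3,4-dimethylphenyl on a sulfonamide nitrogen. Among the compounds with values here, three measured steps bear on this change. The step of a 1.1-fold lower number from compound 1 to compound 2 (0.06 log units; within the scatter) lies within the scatter. The steps of an at least 1.6-fold higher number from compound 1 to compound 3 (0.20 log units; that floor lies within the scatter) and an at least 1.8-fold higher number from compound 2 to compound 3 (0.26 log units; that floor lies within the scatter) give only floors, and both floors lie within the scatter. Compound 4 keeps a chlorinated aryl group, so compound 1 at 62100 nM is the nearest guide. The expected change is modest and towards a lower number, an at least 1.7-fold lower number from compound 3 to compound 4 (0.23 log units; that floor lies within the scatter). For compound 4 the estimate is 58000 nM, with an expected range of 30000 nM to 100000 nM.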

Compound 4, concentration for total growth inhibition: 19600 nM
Beside the measured number, compound 4's estimate is 3.0-fold (0.47 log units) above it; the whole stated range lies above it.
By their numbers in this assay, from the lowest: compound 4; then compounds 2 and 1 (each within the scatter of the next). At a limit, above all of these: compound 3.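

In this assay, iodo in place of chloro on an aromatic carbon gives a 3.2-fold lower number from compound 1 to compound 4 (0.50 log units; beyond the scatter), and iodo in place of hydrogen gives a 2.8-fold lower number from compound 2 to compound 4 (0.44 log units; beyond the scatter), whereas hydrogen in place of chloro gave only a 1.1-fold lower number from compound 1 to compound 2 (0.06 log units; within the scatter). The 3-chloro-4-iodophenyl group in place of 3,4-dimethylphenyl on the sulfonamide nitrogen gives an at least 5.1-fold lower number from compound 3 to compound 4 (0.70 log units; beyond the scatter). Compound 3 is reported only as a limit, so that step is a floor: the limit of > 100000 nM in this assay, at which 1 of the 4 values shown sits.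

On these data alone, whether this drop is particular to iodo remains open. Bromo, methoxy or an amine on that aromatic carbon lie outside the compounds shown.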